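The source may report more compounds than this note shows. Statements on the series, on what has been measured and on what is new or still open speak of the compounds shown alone.

Measured so far:
- Compound 1 `CO[C@@H]1OC(n2cc(F)c(=O)[nH]c2=O)[C@H](OC(C)=O)[C@@H](OC(C)=O)[C@H]1F`: 34000 nM
- Compound 2 `O=C1O/C(=C\Cn2cc(C(F)(F)F)c(=O)[nH]c2=O)C(OCc2ccccc2)=C1OCc1ccccc1`: 2000 nM

In an ADME assay on L1210/0 cells (Mus musculus) for cytotoxicity, with a stated time of 48 h (a lower number here means a stronger inhibitor, a higher number a weaker inhibitor), compound 2 has the lower of the two numbers at 2000 nM, which makes it the stronger inhibitor, and the gap to compound 1 lies beyond the usual scatter. Compound 3 `O=C1O/C(=C\Cn2cc(Br)c(=O)[nH]c2=O)C(OCc2ccccc2)=C1OCc1ccccc1` keeps the core of compound 2 but has bromo in place of trifluoromethyl on an aromatic carbon. For the measured compounds named here, no measured pair shows this kind of swap, so the data offer no direct guide. In this assay, the expected change is small and within the scatter, with the estimated step being a 1.5-fold higher number from compound 2 to compound 3 (0.18 log units; within the scatter). Compound 3 is expected at 3000 nM, with an estimated range of 1000 nM to 10000 nM.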

Compound 3, half-maximal inhibitory concentration: 7500 nM
Compound 3: middle estimate off by 2.5-fold (0.40 log units), on the low side; the measured number falls inside the stated range.
By their numbers in this assay, from the lowest: compound 2; then compound 3; then compound 1.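

In this assay, putting bromo in place of trifluoromethyl gives a 3.8-fold higher number from compound 2 to compound 3 (0.57 log units; beyond the scatter), a modest step beyond the scatter. For the compounds shown here, this is the first comparison of compounds that differ in one place, and it shows that the group on this aromatic carbon affects the number. Nothing measured here explains the direction of this step.

As far as these compounds go, how a nitrile, an amine or a methyl group at this position would compare remains open. So does whether the same swap would give a similar step on a different core.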